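Lengthening the Amine Chain: From Compound 3 to Compound 4

A few compounds are considered here, and "the series" means these few. Any claim that something is new, unique, unknown or untested is made for them only; others in the source may bear on it.

Compound 1 `CCCNc1nc(-c2ccccc2)nc2c1nnn2Cc1ccccc1` gives 37 nM in an assay on Cerebral cortex for displacement of a labelled ligand from adenosine receptor A1 (Bos taurus); on this read-out higher numbers stand for weaker inhibition and lower numbers for stronger inhibition. Compound 2 `CCCNc1nc(-c2ccccc2)nc2c1nnn2Cc1ccccc1F` gives 3.2 nM in this assay, and the step of a 12-fold lower number from compound 1 to compound 2 (1.06 log units; beyond the scatter) came with fluoro in place of hydrogen on an aromatic carbon. Compound 3 `CCCNc1nc(-c2ccccc2)nc2c1nnn2Cc1ccccc1C(F)(F)F` carries a trifluoromethyl group in place of that fluoro; in this assay compound 3 gives "not determined" (no result reported), so no number places it among the others. Compound 4 `CCCCNc1nc(-c2ccccc2)nc2c1nnn2Cc1ccccc1C(F)(F)F` differs from compound 3 by methyl in place of hydrogen on a saturated chain carbon, three bonds along the chain from a nitrogen on an aromatic ring. Within the data shown here, no measured step touches the chain; the single step known concerns the aromatic substituent only, so no direction beyond the scatter can be argued for this change. Compound 4 is therefore estimated at 10 nM, with an expected range from 1.5 nM to 70 nM.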

Compound 4, inhibition constant: 6.5 nM
Compound 4: the middle estimate sits 1.5-fold (0.19 log units) above what was measured; the measured number falls inside the stated range.
By their numbers in this assay, from the lowest: compound 2; then compound 4; then compound 1.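

With no single number for compound 3, the step from compound 3 to compound 4 cannot be read. The compounds shown leave open what propyl to butyl does on its own, and no further data bear on it.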